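Sulfo in Place of a Hydroxyl Hydrogen in Four Amides

The compounds below may be only part of what the source reports. "The series", "measured", "known", "first", "only" and "open" are said of these compounds alone.

Compound 1 `C=CCCC(=O)N[C@H]1[C@@H](OCCc2ccccc2)O[C@H](CO)[C@@H](O)[C@@H]1O` and compound 2 `C=CCCC(=O)N[C@H]1[C@@H](OCCCCCCCCCCCCCCCC)O[C@H](CO)[C@@H](O)[C@@H]1O` share an amide-bearing ring but carry different groups at one oxygen; the difference between the two cores is not broken down here. Compound 3 `C=CCCC(=O)N[C@H]1[C@@H](OCCc2ccccc2)O[C@H](CO)[C@@H](O)[C@@H]1OS(=O)(=O)O` is made from compound 1 by sulfo in place of hydrogen on an oxygen on a saturated carbon. Compound 4 `C=CCCC(=O)N[C@H]1[C@@H](OCCCCCCCCCCCCCCCC)O[C@H](CO)[C@@H](O)[C@@H]1OS(=O)(=O)O` is the unmeasured partner, made from compound 2 by sulfo in place of hydrogen on an oxygen on a saturated carbon, the same change at a place described in the same words.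

In a functional assay on C6 cells (Rattus norvegicus), read by thymidine incorporation (a lower number here means a stronger inhibitor, a higher number a weaker inhibitor), compound 1 gives > 50 uM, which is a limit of the assay and not a number. In this assay compound 2 gives > 50 uM, again a limit. Compound 3 gives > 50 uM, also a limit. The step that the two limits leave unreadable from compound 1 to compound 3 therefore cannot be sized, because of the limit of > 50 uM in this assay, at which 3 of the 3 values shown sit.

For compound 4 the step that the limit leaves unreadable from compound 2 to compound 4 is expected to be similarly unreadable, resting on the limits of compound 2 at > 50 uM and of compound 3 at > 50 uM. Compound 4 is thus estimated at 100 uM in this assay, with a limit again the most likely report.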

Compound 4, concentration for 50% inhibition: 22.6 uM
For compound 4 the middle estimate is 4.4-fold (0.65 log units) above the measured one; low and high end bracket the measured number.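

In this assay, sulfo in place of hydrogen on an oxygen on a saturated carbon gives an at least 2.2-fold lower number from compound 2 to compound 4 (0.34 log units; beyond the scatter), so on this one core the change makes a stronger inhibitor by more than the usual scatter. The same change from compound 1 to compound 3 cannot be read, because both ends of that step are limits of the assay: the limit of > 50 uM in this assay, at which 3 of the 4 values shown sit. The result therefore shows the change working on one core only; it neither shows that the change carries over to the core of compound 1 nor shows that it fails there.

The compounds shown leave open whether a carboxylic acid or a phosphate in place of the sulfooxy group would give a similar step on either core. They also leave open how a chain longer or shorter than that of compound 2 would read in this assay, with or without the sulfo group.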